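Swapping Bromo for Trifluoromethyl on a Sulfonyl Ring

The compounds below may be only part of what the source reports. "The series", "measured", "known", "first", "only" and "open" are said of these compounds alone.

Measured compounds:
- compound 1, `O=C(/C=C/c1ccccc1)c1ccc(N2CCN(c3cccc(Cl)c3)CC2)cc1`, 14.1%
- compound 2, `O=C(/C=C/c1ccccc1)c1ccc(N2CCN(S(=O)(=O)c3ccc(Br)cc3)CC2)cc1`, 47.4%

Going by the values given here, in a functional assay on the whole organism (strain Kunming) for inhibition, with Mus musculus as the target, with a stated time of 1 h, at a dose of 40 mg/kg by the oral route (a lower number here means less inhibition, a higher number more inhibition at the dose given (going by the name of the read-out)), compound 2 stands highest of the two numbers known; its nearest neighbour is compound 1, and the step of a number 33.3 percentage points higher from compound 1 to compound 2 (beyond the scatter). That step exchanges the whole group on the amine nitrogen in the ring, so it does not speak to a small change at the far end of the sulfonyl ring.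

Compound 3, `O=C(/C=C/c1ccccc1)c1ccc(N2CCN(S(=O)(=O)c3ccc(C(F)(F)F)cc3)CC2)cc1`, is not yet measured. It differs from compound 2 only in one place: trifluoromethyl in place of bromo on an aromatic carbon. Among the compounds with values here, no measured pair shows what this exchange does; compounds 1 and 2 differ elsewhere. Without a comparable step, the expectation is a change of no size beyond the scatter, in either direction. For compound 3 the estimated value in this assay is 45%, with a range from 25% to 65%, which is expected to mean a step of a number 2.4 percentage points lower from compound 2 to compound 3 (within the scatter).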

Compound 3, a percentage reported as inhibition, in the whole organism at one dose (the size of the read-out at that dose, not a potency): 47.9%
The estimate for compound 3 lay 2.9 percentage points below the measured number; the range from low to high includes it.
By their numbers in this assay, from the lowest: compound 1; then compounds 2 and 3 (each within the scatter of the next).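

In this assay, trifluoromethyl in place of bromo on an aromatic carbon of the sulfonyl ring gives a number 0.5 percentage points higher from compound 2 to compound 3 (within the scatter). This position therefore accepts a group of four heavy atoms where a single bromine stood, with no difference that can be told from the scatter, something the earlier pair could not show because it exchanged the whole group on the amine nitrogen. Nothing measured here explains why the two compounds read alike.

On these data alone, two groups at one position make no trend, so it remains open whether a quite different group there, such as an amine or a carboxylic acid, would read the same. Also open, as far as these compounds go, is whether a plain hydrogen in that place would keep the number, which would show whether any group is needed there at all.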